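Replacing a Five-Membered Ring in Compound 2

This account rests on a few compounds, and the source may have more. Where it says the series, first, only, none or still open, it means among the compounds named here.

In a functional assay on Bel-7402 cells (Homo sapiens) for inhibition, read by MTT assay, with a stated time of 24 h, tested at 1 ug/mL (on this read-out higher numbers stand for more inhibition of growth at the one concentration tested and lower numbers for less inhibition of growth), compound 1 (`O=C(CCCCC1CCSS1)Nc1cccc(C(F)(F)F)c1`) is reported as "not active" (no number reported) without a number. Compound 2 (`O=C(CCCCC1CCSS1)Nc1ccc([N+](=O)[O-])c(C(F)(F)F)c1`) gives 7.46% and stands within the usual scatter of compound 3 (`O=C(CCCCC(S)CCS)Nc1ccccc1`) at 1.32% on the same read-out. Compound 4 (`O=C(CCCCC(S)CCS)Nc1ccc([N+](=O)[O-])c(C(F)(F)F)c1`) differs from compound 2 in one place (a group of 5 heavy atoms (3 carbon, 2 sulfur; no ring) in place of a group of 5 heavy atoms (3 carbon, 2 sulfur; one five-membered non-aromatic ring with 2 hetero atoms), on a saturated chain carbon, four bonds along the chain from a carbonyl carbon) and has not been measured. Compound 3 at 1.32% also carries the 1,3-disulfanylpropyl group, though it differs from compound 2 elsewhere too, so it offers only a loose guide. In this assay no change beyond the scatter is expected. The estimated step of a number 1.5 percentage points lower from compound 2 to compound 4 (within the scatter) stays within that scatter. Compound 4 is estimated at 6% with an expected range from 0% to 18% for a single measurement.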

Compound 4, percent growth inhibition at one concentration: 0.68%
Compound 4: middle estimate off by 5.3 percentage points, on the high side, and the stated range covers the measured number.
By their numbers in this assay, from the lowest: compounds 4, 3 and 2 (each within the scatter of the next).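

This pair isolates the swap of the five-membered ring for the open 1,3-disulfanylpropyl group, which compound 3 could not do because it also differs elsewhere. In this assay the swap gives a number 6.8 percentage points lower from compound 2 to compound 4 (within the scatter) and so shows no change at this position that stands out from repeat measurements. Nothing measured here offers a cause for the small step.

From the compounds shown here alone, whether an amine or a carboxylic acid at this chain carbon, or a longer chain, would move the number beyond the scatter remains open.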